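Replacing Oxygen with Sulfur on a Semicarbazone Side Chain

A few compounds are considered here, and "the series" means these few. Any claim that something is new, unique, unknown or untested is made for them only; others in the source may bear on it.

Measured compounds in an ADME assay on Vero cells (Chlorocebus sabaeus) for cytotoxicity, read by MTT assay, with a stated time of 96 h; a lower number here means that less compound is tolerated, a higher number that more compound is tolerated:
compound 1 `COc1ccc(-c2nc3cc(/C(C)=N/NC(N)=O)ccc3[nH]2)cc1` — "not determined" (no result reported)
compound 2 `C/C(=N\NC(N)=O)c1ccc2c(c1)nc(-c1ccc(C(F)(F)F)cc1)n2C1CCCCC1` — > 100000 nM
compound 3 `COc1ccc(-c2nc3cc(/C(C)=N/NC(N)=O)ccc3n2C2CCCCC2)cc1` — "not determined" (no result reported)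

Compound 3 has no number of its own in this assay. The value shown for compound 2 is a limit of the assay, not a measured number (the limit of > 100000 nM in this assay, at which 1 of the 3 values shown sits), and compound 1 likewise has no reported value. Compound 4 `COc1ccc(-c2nc3cc(/C(C)=N/NC(N)=S)ccc3n2C2CCCCC2)cc1` differs from compound 3 in one place: a group of 3 heavy atoms (1 carbon, 1 nitrogen, 1 sulfur; no ring) in place of a group of 3 heavy atoms (1 carbon, 1 nitrogen, 1 oxygen; no ring), on an amine nitrogen. Within the data shown here, no measured step between compounds exists here, so the size of the change in this assay cannot be taken from the data; the one value shown sits at the limit, and a step no larger than the usual scatter is expected. Compound 4 is estimated at 70000 nM, within 15000 nM to 200000 nM.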

Compound 4, half-maximal cytotoxic concentration: 40000 nM
Compound 4: middle estimate off by 1.8-fold (0.24 log units), on the high side; measured number inside the range.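

No step can be read between compound 3 and compound 4: compound 3 has no number to set against that of compound 4. The compounds shown leave open what exchanging the side chain's oxygen for sulfur does in this assay.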